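Removing the methoxy group: a change without a direct precedent

The source may hold more compounds than are shown below. What is called first, only, known or untested is meant among the compounds shown, and "the series" means these compounds.

Three compounds share one core and were tested in a functional assay on C6 cells (Rattus norvegicus) for cytotoxicity, read by MTT assay, with a stated time of 24 h, tested at 100 ug/mL; a lower number here means a stronger effect, a higher number a weaker effect of the compound at the concentration tested. Compound 1 `O=C(CSc1nnnn1-c1ccccc1)N/N=c1/scc(-c2ccccc2)n1-c1ccccc1` gives 35.8%, compound 2 `COc1ccc(-c2cs/c(=N/NC(=O)CSc3ncccn3)n2-c2ccccc2)cc1` gives 51.5%, and compound 3 `COc1ccc(-c2cs/c(=N/NC(=O)CSc3nnc(C)s3)n2-c2ccccc2)cc1` gives 25.9%. Compound 3 sits at the low end of these numbers; its gap to compound 1 lies within the scatter, while its gap to compound 2 lies beyond it. Among the measured compounds shown here, the one measured step, a number 25.6 percentage points lower from compound 2 to compound 3 (beyond the scatter), concerns the group on the sulfur and not the ring changed here. Compound 4 `Cc1nnc(SCC(=O)N/N=c2/scc(-c3ccccc3)n2-c2ccccc2)s1` differs from compound 3 by hydrogen in place of methoxy on an aromatic carbon. For the measured compounds named here, no measured step bears on this change, so in this assay no step beyond the scatter is expected: compound 4 is estimated at 30%, between 15% and 47%, a step of a number 4.1 percentage points higher from compound 3 to compound 4 (within the scatter).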

Compound 4, a percentage reported as activity, at one concentration (the size of the read-out at that concentration, not a potency): 61.8%
Beside the measured number, compound 4's estimate is 31.8 percentage points below it, and the stated range ends below it.
By their numbers in this assay, from the lowest: compounds 3 and 1 (each within the scatter of the next); then compound 2; then compound 4.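

Methoxy on this ring carbon turns out to matter in this assay: going from 4-methoxyphenyl to phenyl gives a number 35.9 percentage points higher from compound 3 to compound 4 (beyond the scatter), a clear weakening of the effect. With phenyl in place, the group on the sulfur also counts, with 5-methyl-1,3,4-thiadiazol-2-yl in place of 1-phenyl-1H-tetrazol-5-yl giving a number 26 percentage points higher from compound 1 to compound 4 (beyond the scatter). Nothing available explains why these changes act as they do.

Going by these compounds, it remains open whether a hydroxyl group or a chlorine atom on this carbon would preserve the stronger effect. On these data alone, it is also open whether the same change would shift compound 2 in the same way.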